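The source may report more compounds than this note shows. Statements on the series, on what has been measured and on what is new or still open speak of the compounds shown alone.

Working notes on the series. The shared core carries an amide whose nitrogen substituent is the variable position. Compound 1 `N[C@H]1CC[C@H](Nc2c(C(=O)NCc3ccc(Oc4ccccc4)cc3)nc(Br)c3cccnc23)CC1` and compound 2 `N[C@H]1CC[C@H](Nc2c(C(=O)NCc3cccs3)nc(Br)c3cccnc23)CC1` both belong to the set, but for compound 1 the entry in a functional assay on SK-BR-3 cells (Homo sapiens) for cytotoxicity, read by MTT assay, with a stated time of 72 h (on this read-out lower numbers stand for stronger inhibition and higher numbers for weaker inhibition), reads "not determined" (no result reported), and for compound 2 it likewise reads "not determined" (no result reported), so neither gives a number to lean on. Compound 3 `N[C@H]1CC[C@H](Nc2c(C(=O)Nc3ccccc3)nc(Br)c3cccnc23)CC1` is therefore the only anchor: in this assay compound 3 gives 2000 nM, and it stands alone on the numbers shown, with no second measured neighbour to compare against.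

Compound 4 `N[C@H]1CC[C@H](Nc2c(C(=O)NCc3ccccc3)nc(Br)c3cccnc23)CC1` is the next entry to be measured. It differs from compound 3 in one place: benzyl in place of phenyl on an amide-type nitrogen. The same difference, cut one bond further out, reads anilino to benzylamino.

Going by the values given here, no step between two measured compounds is available in this set, so there is nothing from which to read a direction for this change. The expectation is that the step from compound 3 to compound 4 in this assay stays at or near the scatter, no change at the digits printed from compound 3 to compound 4 (within the scatter), with no reason from the data to expect a shift in either direction. Compound 4 is accordingly estimated at 2000 nM, within a range from 700 nM to 6000 nM.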

Compound 4, half-maximal inhibitory concentration: 8000 nM
Beside the measured number, compound 4's estimate is 4.0-fold (0.60 log units) below it; measured number outside the range, above it.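

Going by these compounds alone, the first readable step at this position is a 4.0-fold higher number from compound 3 to compound 4 (0.60 log units; beyond the scatter) in this assay and it shows that the substituent on the amide nitrogen is not silent on this read-out. Benzyl in place of phenyl keeps the six-membered aromatic ring of carbon and adds a single carbon, and even this small change goes with a weaker result, so the direction for this one swap is now known. The data shown offer no measurement that accounts for the difference.

This direction rests on a single pair of compounds, so it supports no trend with chain length and no rule for other groups at this nitrogen. Going by these compounds, whether a longer chain such as phenethyl weakens the result further, and whether an amine or a carboxylic acid on the benzyl ring alters the step from phenyl to benzyl, remains open.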